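The source may report more compounds than this note shows. Statements on the series, on what has been measured and on what is new or still open speak of the compounds shown alone.

In a functional assay on PANC-1 cells (Homo sapiens) for cytotoxicity, read by WST assay, with a stated time of 24 h (on this read-out lower numbers stand for stronger inhibition and higher numbers for weaker inhibition), compound 1 `O=C(CCCCCCCCCCc1ccccc1)N1CCCCC1` reports only a limit, > 100000 nM. Among the measured compounds shown here, compound 2 `O=C(CCCCCCCCc1ccccc1F)N1CCCCC1` gives 98900 nM, the only actual number so far. For the measured compounds named here, the one measured step, a number no higher from compound 1 to compound 2 (the limit leaves the size open), offers no usable size because of the limit of > 100000 nM in this assay, at which 1 of the 2 values shown sits. Compound 3 `O=C(CCCCCCCCc1cccc(Cl)c1)N1CCCCC1` carries 3-chlorophenyl in place of 2-fluorophenyl on a saturated chain carbon, eight bonds along the chain from a carbonyl carbon. Going by the values given here, with no sized step to draw on, no change beyond the scatter is expected, and the expected move is a 1.2-fold lower number from compound 2 to compound 3 (0.07 log units; within the scatter). Compound 3 is estimated at 85000 nM, with a range of 40000 nM to 150000 nM.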

Compound 3, half-maximal inhibitory concentration: > 100000 nM
Compound 3: a limit, no number; the forecaster's own chance of this, stated with the estimate: 35%; middle value at least 1.1-fold (0.07 log units) away from the limit.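

Replacing 2-fluorophenyl with 3-chlorophenyl at this chain position gives a number no lower from compound 2 to compound 3 (the limit leaves the size open) in this assay, so this change brings no measurable gain in this assay. Neither this step nor the one joining compound 1 and compound 3 can be read for size, because the values stop at the limit: the limit of > 100000 nM in this assay, at which 2 of the 3 values shown sit.

From the compounds shown here alone, whether an aminophenyl or a carboxylic acid in place of 3-chlorophenyl, or a shorter chain, would give a number clearly stronger than that of compound 2 stays open. So does the effect of changing the piperidine amide of the shared core.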